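Cyano for carbamoyl on the shared core

The source may report more compounds than this note shows. Statements on the series, on what has been measured and on what is new or still open speak of the compounds shown alone.

Measured compounds in an assay on isolated protein for inhibition of Leucine-rich repeat serine/threonine-protein kinase 2 variant G2019S (Homo sapiens), read by TR-FRET and LanthaScreen, with stated times of 50 min and 30 min, in the presence of a further agent that is not named here; a lower number here means a stronger inhibitor, a higher number a weaker inhibitor:
compound 1 `Cc1nn(C)cc1Nc1nc(N)c2c(C#N)c(N3CCC[C@H]3C)n(C)c2n1` gives 30 nM
compound 2 `C[C@@H]1CCCN1c1c(C#N)c2c(N)nc(Nc3cn[nH]c3)nc2n1C` gives 6 nM
compound 3 `C[C@@H]1CCCN1c1c(C(N)=O)c2c(N)ncnc2n1C` gives 2240 nM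

Compound 3 stands highest of the three numbers in this assay, that is, it is the weakest inhibitor measured so far. Its nearest neighbour by number is compound 1, with 30 nM, and the furthest is compound 2, with 6 nM; both gaps are well beyond the scatter. Compounds 1 and 2 differ from compound 3 in more than one place, so neither gap can be read as a single change.

Compound 4 `C[C@@H]1CCCN1c1c(C#N)c2c(N)ncnc2n1C` differs from compound 3 in one place: cyano in place of carbamoyl on an aromatic carbon. Going by the values given here, the only single step measured so far, a 5.0-fold lower number from compound 1 to compound 2 (0.70 log units; beyond the scatter), concerns the group on a nitrogen on an aromatic ring and says nothing about carbamoyl or cyano. Among the compounds with values here, no measured step therefore bears directly on the change from compound 3 to compound 4. The two cyano-bearing compounds sit far below compound 3, which gives a loose hint that the cyano is at least tolerated, but the other differences carry an unknown share of those gaps.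

On that basis a modest drop in number is expected, a 3.2-fold lower number from compound 3 to compound 4 (0.51 log units; beyond the scatter), with wide uncertainty. Compound 4 is estimated at 700 nM, within 150 nM to 2500 nM.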

Compound 4, half-maximal inhibitory concentration: 11 nM
Compound 4: the middle estimate sits 64-fold (1.80 log units) above what was measured; measured number outside the range, below it.
By their numbers in this assay, from the lowest: compounds 2 and 4 (each within the scatter of the next); then compound 1; then compound 3.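

Notes on the cyano position: in this assay the exchange of carbamoyl for cyano on an aromatic carbon of the five-membered aromatic ring gives a 200-fold lower number from compound 3 to compound 4 (2.31 log units; beyond the scatter) and, as the only difference between the two structures, isolates the contribution of this group for the first time. The group on the other aromatic carbon proves not to be needed for a low number once cyano is present: hydrogen in place of (1H-pyrazol-4-yl)amino gives a 1.8-fold higher number from compound 2 to compound 4 (0.26 log units; within the scatter) and hydrogen in place of (1,3-dimethyl-1H-pyrazol-4-yl)amino gives a 2.7-fold lower number from compound 1 to compound 4 (0.44 log units; beyond the scatter) so the low numbers of the cyano compounds do not depend on either amino-linked pyrazole. No measurement on hand offers an explanation for the large gap between carbamoyl and cyano.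

On these data alone, how a carboxylic acid, a methyl ester or an aminomethyl group on the same aromatic carbon would compare with cyano remains open. Also open, as far as these compounds go, is whether the gap between carbamoyl and cyano keeps its size when (1H-pyrazol-4-yl)amino is present on the shared core.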